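The source may report more compounds than this note shows. Statements on the series, on what has been measured and on what is new or still open speak of the compounds shown alone.

Of the compounds shown here, three built on one shared core have been tested in a functional assay on A549 cells (Homo sapiens) for inhibition, read by MTT assay, with a stated time of 24 h, tested at 10 uM; on this read-out higher numbers stand for more inhibition of growth at the one concentration tested and lower numbers for less inhibition of growth. Compound 1 `CS(=O)(=O)c1ccc(-c2cnc3[nH]cc(-c4nnc(-c5ccc(Cl)cc5)o4)c(=O)c3c2)cc1` gives 26.8%. Compound 2 `CS(=O)(=O)c1ccc(-c2cnc3[nH]cc(-c4nnc(-c5ccc(F)cc5)o4)c(=O)c3c2)cc1` gives 3.59%. Compound 3 `O=c1c(-c2nnc(-c3ccc(Cl)cc3)o2)c[nH]c2ncc(-c3ccccc3)cc12` gives 9.77%. Of these three numbers, compound 2 holds the lowest; its gap to compound 3 lies within the usual scatter, while its gap to compound 1 lies beyond it.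

Two single changes have been measured. One is a number 23.2 percentage points lower from compound 1 to compound 2 (beyond the scatter). The other is a number 17 percentage points lower from compound 1 to compound 3 (beyond the scatter).

Compound 4 `Cc1cccc(-c2nnc(-c3c[nH]c4ncc(-c5ccc(S(C)(=O)=O)cc5)cc4c3=O)o2)c1` differs from compound 2 in one place: 3-methylphenyl in place of 4-fluorophenyl on an aromatic carbon. For the measured compounds named here, no measured pair swaps a fluorine for a methyl on this ring, so there is no direct precedent. The step that bears on the change is a number 23.2 percentage points lower from compound 1 to compound 2 (beyond the scatter). It alters the group on the same phenyl ring and shows that such a swap can move this assay by a modest amount. A modest step in this assay is therefore expected, more likely upward than downward, though a result within the scatter of compound 2 cannot be ruled out. Compound 4 is estimated at 15%, with a range from 0% to 35%. The expected step is a number 11.4 percentage points higher from compound 2 to compound 4 (beyond the scatter).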

Compound 4, percent growth inhibition at one concentration: 8.95%
Compound 4: middle estimate off by 6.1 percentage points, on the high side; the range from low to high includes it.
By their numbers in this assay, from the lowest: compounds 2, 4 and 3 (each within the scatter of the next); then compound 1.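

Placing 3-methylphenyl on the aromatic carbon of the five-membered aromatic ring with 2 nitrogen and 1 oxygen, in place of 4-fluorophenyl, gives a number 5.4 percentage points higher from compound 2 to compound 4 (within the scatter) in this assay, so this swap cannot be told apart from no change. Against the 4-chlorophenyl group, the same 3-methylphenyl group gives a number 17.9 percentage points lower from compound 1 to compound 4 (beyond the scatter), which shows that among compounds 1, 2 and 4, which differ only in this group, 4-chlorophenyl alone stands apart from the other two. No measurement shown here explains this difference.

The step from 4-chlorophenyl to 3-methylphenyl alters both the substituent and where it sits on the phenyl ring, so the compounds shown leave open which of the two matters; 3-chlorophenyl and 4-methylphenyl would separate them. Also open, from the compounds shown here alone, is how this assay would respond to a quite different group at this position, such as a phenyl ring carrying an amine or a carboxylic acid, or a longer chain in place of the ring.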